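Same atoms, opposite drawn stereocentre: compound 3

The source may report more compounds than this note shows. Statements on the series, on what has been measured and on what is new or still open speak of the compounds shown alone.

Measured in an ADME assay on MDCK cells (Canis lupus familiaris) for permeability, read by LC-MS, with a stated time of 90 min, tested at 2 uM; on this read-out lower numbers stand for lower permeability and higher numbers for higher permeability:
- compound 1 `COc1cc(C)[nH]c(=O)c1CN1CCc2c(Cl)cc(-c3c(C)noc3C)c(Cl)c2C1=O`: 11 10^-6 cm/s
- compound 2 `COc1cc(C)[nH]c(=O)c1CN1CCc2c(Cl)cc([C@H](O)C3COC3)c(Cl)c2C1=O`: 0.7 10^-6 cm/s

Of the two, compound 2 stands lower, at 0.7 10^-6 cm/s. Compound 3 `COc1cc(C)[nH]c(=O)c1CN1CCc2c(Cl)cc([C@@H](O)C3COC3)c(Cl)c2C1=O` is not yet measured and differs from it in one way: the two compounds have the same atoms and bonds and differ only in configuration as drawn: 1 of 1 stereo elements differ; a stereocentre at a saturated chain carbon is drawn R in compound 2 and S in compound 3. Within the data shown here, the only measured step, a 16-fold lower number from compound 1 to compound 2 (1.20 log units; beyond the scatter), swapped a whole group, and no measured pair shows what a change of configuration alone does. No size or direction can be drawn from it, so no step beyond the scatter is expected in this assay. The expected size is no change at the digits printed from compound 2 to compound 3 (within the scatter). The estimate for compound 3 is 0.7 10^-6 cm/s, with an expected range of 0.3 10^-6 cm/s to 1.8 10^-6 cm/s.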

Compound 3, apparent permeability: 1.2 10^-6 cm/s
For compound 3 the middle estimate is 1.7-fold (0.23 log units) below the measured one; low and high end bracket the measured number.
By their numbers in this assay, from the lowest: compounds 2 and 3 (each within the scatter of the next); then compound 1.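

In this assay, among these compounds, there is a 1.7-fold higher number from compound 2 to compound 3 (0.23 log units; within the scatter), the first measured change of configuration alone, so the two drawn forms of this stereocentre at a saturated chain carbon cannot be told apart here. Replacing the five-membered aromatic ring group still gives a 9.2-fold lower number from compound 1 to compound 3 (0.96 log units; beyond the scatter) with the other drawn form. This pair isolates a single change: the fact that compounds 2 and 3 differ only in the configuration as drawn.

The compounds shown leave open how an amine, a carboxylic acid or a longer chain on this aromatic carbon would read in this assay.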